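From dimethylamino to 4-methylpiperazin-1-yl on a shared core

The source may report more compounds than this note shows. Statements on the series, on what has been measured and on what is new or still open speak of the compounds shown alone.

Compound 1 (`CN1CCN(CCCN2CCC3(N(C)C)CC(c4ccccc4)C2C(c2ccccc2)C3)CC1`) gives 54500 nM in an ADME assay on L6 cells (Rattus norvegicus) for cytotoxicity (on this read-out higher numbers stand for weaker inhibition and lower numbers for stronger inhibition), as its measured value. Two relatives help to place it. Compound 2 (`CN1CCN(CCC(=O)OC2CC3(N(C)C)CC(c4ccccc4)C2C(c2ccccc2)C3)CC1`) gives 31100 nM as its reading, and compound 3 (`CN1CCN(CCC(=O)NC2CC3(N4CCN(C)CC4)CC(c4ccccc4)C2C(c2ccccc2)C3)CC1`) gives 67900 nM as its reading. Compound 1 lies within the usual scatter of each of these two, so its number cannot be told apart from either of theirs.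

Compound 4 (`CN1CCN(CCCN2CCC3(N4CCN(C)CC4)CC(c4ccccc4)C2C(c2ccccc2)C3)CC1`) keeps the core and side chain of compound 1 and changes one group: 4-methylpiperazin-1-yl in place of dimethylamino on a saturated ring carbon. Among the measured compounds shown here, no two measured compounds differ in one place only, so the data offer no direct measure of this swap. The nearest clue stays within the scatter of compound 1: compound 3, which also carries 4-methylpiperazin-1-yl on a saturated ring carbon, gives 67900 nM in this assay even though it differs elsewhere too. That clue is modest, but it gives no sign of a large shift, so no change beyond the scatter is expected. The estimated change is small, a 1.1-fold lower number from compound 1 to compound 4 (0.04 log units; within the scatter) in this assay as the expected step. The estimate for compound 4 is 50000 nM with an expected range from 24000 nM to 100000 nM in this measurement.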

Compound 4, half-maximal inhibitory concentration: 47800 nM
The estimate for compound 4 lay 1.0-fold (0.02 log units) above the measured number, within the range that was stated.
By their numbers in this assay, from the lowest: compounds 2, 4, 1 and 3 (each within the scatter of the next, the first and the last beyond it).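

Among the compounds shown here, the pair of compound 1 and compound 4 gives the first direct reading of this swap on a saturated ring carbon: in this assay, putting 4-methylpiperazin-1-yl in place of dimethylamino gives a 1.1-fold lower number from compound 1 to compound 4 (0.06 log units; within the scatter). With the core and side chain held the same, a group carrying a six-membered non-aromatic ring can therefore replace one with no ring at this position without a change that can be told from ordinary repeat scatter, although this rests on a single pair of compounds in this assay. No supporting measurement is available to explain why these two numbers cannot be told apart.

Every other pair among the compounds shown differs in more than one place, so no further steps can be read, and it stays open whether the same swap would behave alike with the ester side chain of compound 2 or the amide side chain of compound 3. Also open, going by these compounds, is whether other groups on this ring carbon, such as a primary amine or morpholin-4-yl, would leave the number equally unmoved.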